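Para substituent variation on the benzamide of the shared core

The compounds below may be only part of what the source reports. "The series", "measured", "known", "first", "only" and "open" are said of these compounds alone.

Three amides on the shared core have been measured in an assay on CHO cells with metabotropic glutamate receptor 5 (Homo sapiens) as the target; on this read-out higher numbers stand for an effect only at larger amounts of compound and lower numbers for an effect already at smaller amounts. Compound 1 `O=C(Nc1cc(-c2ccccc2)nn1-c1ccccc1)c1ccc(F)cc1` gives 30 nM. Compound 2 `O=C(Nc1cc(-c2ccccc2)nn1-c1ccccc1)c1cccc(F)c1` gives 20 nM. Compound 3 `O=C(Nc1cc(-c2ccccc2)nn1-c1ccccc1)c1ccc(Cl)cc1` gives 20 nM, level with compound 2 and together with it the lowest of the three numbers, though every step among them sits within the scatter: a 1.5-fold lower number from compound 1 to compound 2 (0.18 log units; within the scatter), no change at the digits printed from compound 2 to compound 3 (within the scatter). None of the three changes on the benzoyl ring has moved this assay beyond its noise.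

Compound 4 `O=C(Nc1cc(-c2ccccc2)nn1-c1ccccc1)c1ccc(C(F)(F)F)cc1` carries the change (trifluoromethyl in place of chloro on an aromatic carbon). The step that bears most directly on it is the exchange of one halogen for another in the same place, a 1.5-fold lower number from compound 1 to compound 3 (0.18 log units; within the scatter), which stayed within the scatter. The move from compound 2 to compound 3, which also ends at the same para-chloro group, gave no change either. Among the compounds with values here, no measured compound carries a trifluoromethyl group, so the substitution itself is untested here; the record shows only that this position has tolerated every variation tried without a step beyond the scatter.

The expectation is therefore a step of no change at the digits printed from compound 3 to compound 4 (within the scatter) in this assay, in no direction beyond the scatter. Compound 4 is estimated at 20 nM, with a range from 7 nM to 60 nM.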

Compound 4, half-maximal effective concentration: 19 nM
Estimate against measurement, compound 4: 1.1-fold (0.02 log units) above; low and high end bracket the measured number.
By their numbers in this assay, from the lowest: compounds 4, 2, 3 and 1 (each within the scatter of the next).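

In this assay, trifluoromethyl, with 4 heavy atoms, takes the place of chloro, with 1, on an aromatic carbon para to a large group, and the step stays within the scatter (a 1.1-fold lower number from compound 3 to compound 4 (0.02 log units; within the scatter)). Within the data shown here, the same holds against the two fluoro compounds (a 1.6-fold lower number from compound 1 to compound 4 (0.20 log units; within the scatter); a 1.1-fold lower number from compound 2 to compound 4 (0.02 log units; within the scatter)), so the tolerance seen so far among halogens at this part of the molecule now extends to a group that is not a single atom, and no pair among the four compounds is separated by a step beyond the scatter. No measurement available here accounts for this lack of response to the exchange.

The compounds shown leave open whether this tolerance has a limit, as an amine, a carboxylic acid or a longer chain such as n-butyl on this aromatic carbon could read differently from the halogens and trifluoromethyl. Going by these compounds, the rest of the shared core stays the same throughout, so the response of this assay to a change anywhere outside the benzoyl ring also remains open.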